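The source may report more compounds than this note shows. Statements on the series, on what has been measured and on what is new or still open speak of the compounds shown alone.

Measured compounds:
- compound 1, `COc1ccc(Br)cc1C(C)NC(=O)NS(=O)(=O)c1ccc(Cl)cc1`: 80900 nM
- compound 2, `COc1ccc(F)cc1C(C)NC(=O)NS(=O)(=O)c1ccc(Cl)cc1`: > 300000 nM

Compound 1 was tested in a functional assay on thoracic aorta (Rattus norvegicus, strain Wistar), with a stated time of 15 min (a lower number here means that less compound is needed, a higher number that more compound is needed for the effect), and gives 80900 nM. It stands as the only true number shown for this read-out; the other value shown is a limit of the assay. That limit belongs to compound 2, which in this assay gives > 300000 nM (the limit of > 300000 nM in this assay, at which 1 of the 2 values shown sits). Among the compounds with values here, the single measured step, an at least 3.7-fold higher number from compound 1 to compound 2 (0.56 log units; beyond the scatter), is fluoro in place of bromo on an aromatic carbon, and it goes toward the limit.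

Compound 3, `CC(NC(=O)NS(=O)(=O)c1ccc(Cl)cc1)c1cc(Br)ccc1OCc1ccccc1`, is not yet measured in this assay. It differs from compound 1 by phenyl in place of hydrogen on a saturated chain carbon bound to an oxygen on an aromatic ring. No measured step touches this part of the molecule: the one step shown changes the halogen on the aromatic ring, not the group on the oxygen, so it gives no direction for the change from methoxy to benzyloxy. With nothing to point either way, the expected step is a 1.0-fold lower number from compound 1 to compound 3 (0.00 log units; within the scatter), none beyond the scatter, and the expectation is held loosely. Compound 3 is therefore estimated at 80000 nM in this assay, with a range from 20000 nM to 300000 nM.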

Compound 3, half-maximal effective concentration: 57500 nM
Beside the measured number, compound 3's estimate is 1.4-fold (0.14 log units) above it; the measured number falls inside the stated range.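

In this assay, the change at the group on the oxygen gives a 1.4-fold lower number from compound 1 to compound 3 (0.15 log units; within the scatter), so methoxy and benzyloxy cannot be told apart in this read-out. Within the data shown here, the one earlier step spoke only of the halogen on the aromatic ring, whereas this result is the first to concern the saturated chain carbon bound to the oxygen, and it shows that a phenyl placed there, with its six added heavy atoms, leaves the number where it was within the usual scatter of repeated measurements. The halogen change thus remains the only step beyond the scatter, and the only limit among the values is still that of compound 2: the limit of > 300000 nM in this assay, at which 1 of the 3 values shown sits.

What the compounds shown leave open is whether this tolerance holds for other groups on the same oxygen, such as a longer chain, a pyridylmethyl or a benzyl carrying a carboxylic acid, or for a free hydroxyl in place of the ether. They also leave open whether benzyloxy would give a measurable number with fluoro on the aromatic ring instead of bromo.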